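Swapping chloro for hydrogen on an aromatic carbon

The compounds below may be only part of what the source reports. "The series", "measured", "known", "first", "only" and "open" are said of these compounds alone.

compound 1 `O=C(NCc1ccc(-c2ccccc2)cc1)c1cc(Br)c(Br)[nH]1`: 21000 nM
compound 2 `O=C(NCc1ccc(Cl)c(Cl)c1)c1cc(Br)c(Br)[nH]1`: 19000 nM
compound 3 `O=C(NCc1ccc(Cl)cc1)c1cc(Br)c(Br)[nH]1`: 28000 nM

All three compounds share one core and were tested in a functional assay on NCI-H460 cells (Homo sapiens) for inhibition, read by MTT assay, with a stated time of 72 h; on this read-out lower numbers stand for stronger inhibition of growth and higher numbers for weaker inhibition of growth. In that test compound 3 gives 28000 nM, and it cannot be told apart from the other two: the record shows a 1.3-fold higher number from compound 1 to compound 3 (0.12 log units; within the scatter), and also a 1.5-fold higher number from compound 2 to compound 3 (0.17 log units; within the scatter).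

Compound 4 `O=C(NCc1ccccc1)c1cc(Br)c(Br)[nH]1` has not yet been measured. It differs from compound 3 in a single place: hydrogen in place of chloro on an aromatic carbon. This is hydrogen in place of chloro on an aromatic carbon, para to a large group.

Going by the values given here, two measured steps bear on this change. The closer one is the same kind of swap, hydrogen in place of chloro, and it gave a 1.5-fold higher number from compound 2 to compound 3 (0.17 log units; within the scatter). The other put chloro in place of phenyl, and it gave a 1.3-fold higher number from compound 1 to compound 3 (0.12 log units; within the scatter). Neither step left the scatter. Among the compounds with values here, none of the measured compounds carries hydrogen at the place that changes, however, so the comparison is only a guide. No step beyond the scatter is therefore expected in this assay, with at most a slight drift towards weaker inhibition. The expected step is a 1.1-fold higher number from compound 3 to compound 4 (0.06 log units; within the scatter). For compound 4 the estimated value is 32000 nM, with an expected range of 17000 nM to 58000 nM.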

Compound 4, concentration for 50% growth inhibition: 35000 nM
For compound 4 the middle estimate is 1.1-fold (0.04 log units) below the measured one; low and high end bracket the measured number.
By their numbers in this assay, from the lowest: compounds 2, 1, 3 and 4 (each within the scatter of the next).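

Going by these compounds alone, compound 4 is the first compound here with only hydrogen at this place on the six-membered aromatic ring, so it shows what happens when the substituent is removed altogether: in this assay the record gives a 1.3-fold higher number from compound 3 to compound 4 (0.10 log units; within the scatter) and, against the much larger phenyl, a 1.7-fold higher number from compound 1 to compound 4 (0.22 log units; within the scatter) for the same place. Neither step leaves the scatter, so chloro, phenyl and hydrogen cannot be told apart at this position, and even taking away the whole phenyl group produces no measurable change in growth inhibition in these cells. No accompanying measurement offers an explanation for this flat result.

The compounds shown leave open whether any group at this place can move the number beyond the scatter, for instance an amine, a carboxylic acid or a longer chain such as a butyl group. They also leave open whether the number responds to changes elsewhere in the molecule, such as replacing the two bromo groups on the shared core or the amide hydrogen.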